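The source may hold more compounds than are shown below. What is called first, only, known or untested is meant among the compounds shown, and "the series" means these compounds.

In an ADME assay on Vero 76 cells (Chlorocebus sabaeus) for cytotoxicity, read by MTT assay, with a stated time of 96 h (a lower number here means that less compound is tolerated, a higher number that more compound is tolerated), compound 1 `Cc1ccc(C2CC(c3ccccc3)=NN2c2ccc(S(N)(=O)=O)cc2)cc1` gives 20000 nM. Compound 2 `NS(=O)(=O)c1ccc(N2N=C(c3ccc(OCc4ccccc4)cc3)CC2c2ccccc2)cc1` reads > 100000 nM, which is a limit of the assay and not a number. Compound 3 `NS(=O)(=O)c1ccc(N2N=C(c3ccc(OCc4ccccc4)cc3)CC2c2cccc(Cl)c2)cc1` differs from compound 2 in one place, with chloro in place of hydrogen on an aromatic carbon, meta to a large group: chloro in place of hydrogen on an aromatic carbon. Within the data shown here, no measured pair shows this change, so the expectation is loose. The expected step of an at least 1.2-fold lower number from compound 2 to compound 3 (0.09 log units; that floor lies within the scatter) is modest and points, if anywhere, towards less compound being tolerated in this assay. For compound 3 the estimated value is 80000 nM, with an expected range from 30000 nM to 100000 nM.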

Compound 3, half-maximal cytotoxic concentration: 85000 nM
The estimate for compound 3 lay 1.1-fold (0.03 log units) below the measured number; the range from low to high includes it.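

Chloro in place of hydrogen, turning phenyl into 3-chlorophenyl, gives an at least 1.1-fold lower number from compound 2 to compound 3 (0.07 log units; that floor lies within the scatter) in this assay, so no real drop in tolerated compound is shown. Compound 2 reads > 100000 nM, which is a limit of the assay and not a number. From the compounds shown here alone, the true size of the step therefore stays unknown, because compound 2 sits at the edge of what can be read: the limit of > 100000 nM in this assay, at which 1 of the 3 values shown sits. Going by these compounds, whether chloro behaves the same elsewhere on this ring remains open, as does what an amine or a carboxylic acid would do at this position.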